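Removing the ring fluorine from compound 1

The compounds below may be only part of what the source reports. "The series", "measured", "known", "first", "only" and "open" are said of these compounds alone.

The series rests on a shared core, with compound 1 `N/C(=N\NC(=S)N1CCCC1)c1ccc(F)cn1` and compound 2 `N/C(=N\NC(=S)N1CCSCC1)c1ccc(F)cn1` measured so far. In a functional assay on A-431 cells (Homo sapiens) for cytotoxicity, read by MTT assay, with a stated time of 72 h (on this read-out higher numbers stand for weaker inhibition and lower numbers for stronger inhibition), compound 1 gives 1000 nM. Compound 2, with thiomorpholin-4-yl in place of pyrrolidin-1-yl on the thiocarbonyl carbon, gives 1200 nM in this assay; the step of a 1.2-fold higher number from compound 1 to compound 2 (0.08 log units; within the scatter) does not separate the two. Compound 1 thus holds the lower of the two numbers, though not apart from compound 2 beyond the scatter.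

Compound 3 `N/C(=N\NC(=S)N1CCCC1)c1ccccn1` is not yet measured. It differs from compound 1 by hydrogen in place of fluoro on an aromatic carbon. Within the data shown here, no measured step touches this position: the one step known changes only the amine on the thiocarbonyl carbon and stays within the scatter. Nothing here speaks for a step beyond the scatter in this assay in either direction. The expected value for compound 3 is 1200 nM, with a range from 500 nM to 3000 nM. The expected step is a 1.2-fold higher number from compound 1 to compound 3 (0.08 log units; within the scatter).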

Compound 3, half-maximal inhibitory concentration: 1700 nM
Estimate against measurement, compound 3: 1.4-fold (0.15 log units) below; measured number inside the range.
By their numbers in this assay, from the lowest: compounds 1, 2 and 3 (each within the scatter of the next).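

Hydrogen in place of fluoro on an aromatic carbon, two atoms from the ring nitrogen and para to a large group, gives the first step in the series that leaves the amine on the thiocarbonyl carbon untouched. In this assay this exchange gives a 1.7-fold higher number from compound 1 to compound 3 (0.23 log units; within the scatter), so the fluoro is not required for a number in this range, and this pair gives no sign that the position is sensitive to this exchange. The series now has one step at the amine and one on the aromatic ring, and neither lies beyond the scatter, although a single pair cannot define what the position tolerates in general. No measurement to hand bears on what lies behind this step.

As far as these compounds go, whether chlorine, a methoxy group or an amine at this position would give a step beyond the scatter remains open. From the compounds shown here alone, it is also open whether hydrogen in place of fluoro would read the same way with the thiomorpholin-4-yl group of compound 2 as it does with the pyrrolidin-1-yl group of compound 1.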